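Removing a Chloro Group: What Compound 4 Might Show

The source may hold more compounds than are shown below. What is called first, only, known or untested is meant among the compounds shown, and "the series" means these compounds.

Of the compounds shown here, three have been measured in a functional assay on MCF7 cells (Homo sapiens) for cytotoxicity, read by MTT assay, with a stated time of 72 h; a higher number here means a weaker inhibitor, a lower number a stronger inhibitor. Compound 1 `O=C(NC(=S)NNc1ncnc2ccccc12)c1ccccc1` gives 5960 nM. Compound 2 `O=C(NC(=S)NNc1ncnc2ccccc12)c1ccc(Cl)cc1` gives 5960 nM. Compound 3 `COc1cc2ncnc(NNC(=S)NC(=O)c3cccc(Cl)c3)c2cc1OC` gives 11500 nM, and all three numbers lie close together. Compound 4 `COc1cc2ncnc(NNC(=S)NC(=O)c3ccccc3)c2cc1OC` has not yet been measured.

Compound 1 and compound 2 differ in one place only: hydrogen in place of chloro on an aromatic carbon. This change made no change at the digits printed from compound 2 to compound 1 (within the scatter). Compound 3 is built on a different core from compound 2, and the difference between the two cores is not broken down here. Compound 4 differs from compound 3 by hydrogen in place of chloro on an aromatic carbon. Among the measured compounds shown here, that is the same kind of change as the one between compound 2 and compound 1, though not the same: in compound 2 the chloro sits para to a large group, while in compound 3 it sits meta to a large group.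

Because the same kind of change made no change at the digits printed from compound 2 to compound 1 (within the scatter), the expected step from compound 3 to compound 4 is a 1.0-fold lower number from compound 3 to compound 4 (0.02 log units; within the scatter). For compound 4 in this assay the estimate is 11000 nM, expected to fall between 5000 nM and 25000 nM.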

Compound 4, half-maximal inhibitory concentration: 6990 nM
Compound 4: middle estimate off by 1.6-fold (0.20 log units), on the high side, and the stated range covers the measured number.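

In this assay, putting phenyl in place of 3-chlorophenyl gives a 1.6-fold lower number from compound 3 to compound 4 (0.22 log units; within the scatter), so on this core the chloro group leaves the number inside the usual spread of repeat measurements. Set beside the same swap on the core of compound 1 and compound 2, the two steps do not differ by more than that spread: the same change on two cores in this assay, no change at the digits printed (within the scatter) from compound 2 to compound 1 and a 1.6-fold lower number (0.22 log units; within the scatter) from compound 3 to compound 4, 1.6-fold (0.22 log units) apart, within the scatter of two such steps. This shows that the swap behaves alike on the two cores in this one assay, but neither step stands clear of the scatter, so there is no measurable effect here to carry across, and two cores give no rule for a third.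

The compounds shown leave open whether a different group on this phenyl ring, such as an amine or a carboxylic acid, would move the number beyond the scatter. They also leave open what happens when the sulfur of the linking chain is replaced by oxygen.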